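From methyl to methoxy: what follows compound 3?

The compounds below may be only part of what the source reports. "The series", "measured", "known", "first", "only" and "open" are said of these compounds alone.

In an ADME assay on HPC cells (Homo sapiens) for cytotoxicity, with a stated time of 24 h (on this read-out lower numbers stand for higher toxicity in this test and higher numbers for lower toxicity in this test), compound 1 `O=C1/C(=C/c2ccc(Cl)cc2)CCC/C1=C\c1cccc([N+](=O)[O-])c1`, which carries chloro, gives 18000 nM. Within the data shown here, compound 3 `Cc1ccc(/C=C2\CCC/C(=C\c3cccc([N+](=O)[O-])c3)C2=O)cc1`, which carries methyl, gives 192000 nM, the higher of the two exact numbers so far. Compound 2 `CN(C)c1ccc(/C=C2\CCC/C(=C\c3cccc([N+](=O)[O-])c3)C2=O)cc1`, which carries dimethylamino, reads > 400000 nM, and this is a limit of the assay. Compound 4 `COc1ccc(/C=C2\CCC/C(=C\c3cccc([N+](=O)[O-])c3)C2=O)cc1` is unmeasured: methoxy replaces methyl on an aromatic carbon, para to a large group (methoxy in place of methyl on an aromatic carbon). Among the measured compounds shown here, the steps that bear on this are an 11-fold higher number from compound 1 to compound 3 (1.03 log units; beyond the scatter), which is large, and an at least 2.0-fold lower number from compound 2 to compound 3 (0.31 log units; beyond the scatter), which is at least modest. Neither step swaps methyl for methoxy, so only a small change is expected, with the number staying high. The expected step is a 1.0-fold higher number from compound 3 to compound 4 (0.02 log units; within the scatter). For compound 4 the estimate is 200000 nM, with an expected range from 80000 nM to 400000 nM.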

Compound 4, half-maximal cytotoxic concentration: 33000 nM
Compound 4: the middle estimate sits 6.1-fold (0.78 log units) above what was measured; measured number below the stated range.
By their numbers in this assay, from the lowest: compounds 1 and 4 (each within the scatter of the next); then compound 3. At a limit, above all of these: compound 2.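

In this assay, methoxy in place of methyl at this position is not a neutral swap: the result is a 5.8-fold lower number from compound 3 to compound 4 (0.76 log units; beyond the scatter). Methoxy and chloro cannot be told apart here, with a 1.8-fold higher number from compound 1 to compound 4 (0.26 log units; within the scatter). Compound 2 stands at a limit, so an at least 12-fold lower number from compound 2 to compound 4 (1.08 log units; beyond the scatter) gives only a bound: the limit of > 400000 nM in this assay, at which 1 of the 4 values shown sits.

The compounds shown leave open what hydroxy or ethoxy would read at this position. They also leave open whether the methyl-to-methoxy step would hold on a core without the shared nitro group.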